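The source may hold more compounds than are shown below. What is called first, only, known or untested is meant among the compounds shown, and "the series" means these compounds.

Working notes on the series. Compound 1 `O=C(Nc1cccc(-n2cc(-c3ccncc3)c(-c3cc(O)cc(Cl)c3)n2)c1)Nc1ccc(Cl)c(C(F)(F)F)c1` gives 55% in a functional assay on K562 cells (Homo sapiens) for inhibition, read by sulforhodamine B assay, with a stated time of 48 h, tested at 1 uM; a higher number here means a weaker effect of the compound at the concentration tested, a lower number a stronger effect. Among the compounds with values here, compound 2 `O=C(Nc1cccc(-n2cc(-c3ccncc3)c(-c3cc(O)cc(Cl)c3)n2)c1)Nc1ccc(Cl)c(Cl)c1` gives 83% in this assay; the one single-place step measured so far, a number 28 percentage points higher from compound 1 to compound 2 (beyond the scatter), is chloro in place of trifluoromethyl on an aromatic carbon. Compound 3 `COc1cc(Cl)cc(-c2nn(-c3cccc(NC(=O)Nc4cc(C(F)(F)F)cc(C(F)(F)F)c4)c3)cc2-c2ccncc2)c1` gives 18% in this assay, the lowest of the three numbers, with compound 1 nearer to it and compound 2 further away, both beyond the scatter; neither pair is a single-place step.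

Compound 4 `COc1cc(Cl)cc(-c2nn(-c3cccc(NC(=O)Nc4cccc(C(F)(F)F)c4)c3)cc2-c2ccncc2)c1` has not yet been measured in this assay. It differs from compound 3 by hydrogen in place of trifluoromethyl on an aromatic carbon. Within the data shown here, the only measured step that bears on this is a number 28 percentage points higher from compound 1 to compound 2 (beyond the scatter), where a trifluoromethyl was lost in favour of chloro and the number rose by a modest amount. In the present change a trifluoromethyl is lost outright while the second trifluoromethyl on the same ring is kept, so a rise of comparable size, beyond the scatter, is expected in this assay, with the size uncertain because compound 3 starts from 18% on the core it shares with compound 4. Compound 4 is therefore estimated at 45%, with a range from 25% to 70%. The expected step is a number 27 percentage points higher from compound 3 to compound 4 (beyond the scatter).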

Compound 4, a percentage reported as activity, at one concentration (the size of the read-out at that concentration, not a potency): 45%
Compound 4: middle estimate and measured number agree at the digits printed; measured number inside the range.
By their numbers in this assay, from the lowest: compound 3; then compounds 4 and 1 (each within the scatter of the next); then compound 2.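

In this assay, within the data shown here, the step of a number 27 percentage points higher from compound 3 to compound 4 (beyond the scatter) is the first case where a trifluoromethyl leaves with only hydrogen entering, on an aromatic carbon meta to a trifluoromethyl group. As a higher number means a weaker effect at the concentration tested, the trifluoromethyl kept on that ring does not by itself hold the value of compound 3, so the one that leaves counts in its own right on this core. Alongside a number 28 percentage points higher from compound 1 to compound 2 (beyond the scatter), this gives two steps in which a trifluoromethyl leaves and the number rises, but they stand on different compounds and show no rule for the series, and nothing available accounts for either rise.

The compounds shown leave open whether a methyl, a nitrile or an amine on this aromatic carbon of the core of compound 3 would keep the number near that of compound 3 or near that of compound 4. They also leave open whether the same removal would give a step of similar size on the core of compound 1, which carries a hydroxy where compound 3 carries a methoxy.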